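The source may hold more compounds than are shown below. What is called first, only, known or untested is meant among the compounds shown, and "the series" means these compounds.

Among the measured compounds shown here, in a functional assay on VCaP cells (Homo sapiens) for antiproliferative activity, read by propidium iodide staining, with a stated time of 96 h (on this read-out higher numbers stand for weaker inhibition and lower numbers for stronger inhibition), only two compounds have numbers so far. Compound 1 (`CC(O)(CSc1cccc(S(F)(F)(F)(F)F)c1)C(=O)Nc1ccc([N+](=O)[O-])c(C(F)(F)F)c1`) gives 9800 nM, and compound 2 (`CC(O)(CSc1ccc(S(F)(F)(F)(F)F)cc1)C(=O)Nc1ccc(S(F)(F)(F)(F)F)cc1`) gives 28000 nM. Compound 2 therefore stands highest of the two, on the side of weaker inhibition, and its gap to compound 1 lies beyond the usual scatter. Compound 3 (`CC(O)(CSc1ccc(OC(F)(F)F)cc1)C(=O)Nc1ccc(S(F)(F)(F)(F)F)cc1`) has not yet been measured in this assay. It differs from compound 2 in one place: a group of 5 heavy atoms (1 carbon, 1 oxygen, 3 fluorine; no ring) in place of a group of 6 heavy atoms (5 fluorine, 1 sulfur; no ring), on an aromatic carbon, on an aromatic carbon of a six-membered aromatic ring of carbon only, para to a large group. For the measured compounds named here, no measured pair of compounds isolates a change of this kind, so the data give no direct guide to its size. Only a small shift toward a lower number, within the scatter, is expected, estimated as a 1.4-fold lower number from compound 2 to compound 3 (0.15 log units; within the scatter). For compound 3 the estimated value is 20000 nM, with an expected range from 8000 nM to 45000 nM.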

Compound 3, half-maximal inhibitory concentration: 16000 nM
For compound 3 the middle estimate is 1.3-fold (0.10 log units) above the measured one; the measured number falls inside the stated range.
By their numbers in this assay, from the lowest: compounds 1, 3 and 2 (each within the scatter of the next, the first and the last beyond it).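

In this assay, among the compounds shown here, the change from the group of 6 heavy atoms (5 fluorine, 1 sulfur) to trifluoromethoxy, on an aromatic carbon para to a large group, is the first change that a measured pair isolates, and it gives a 1.8-fold lower number from compound 2 to compound 3 (0.24 log units; within the scatter) and so no separation between the two groups. At this position, then, trifluoromethoxy can stand in for the larger group on this read-out, even though it brings 1 hydrogen-bond acceptor where the group it replaces has none. No measurement at hand explains this result.

The compounds shown leave open how an amine, a nitrile or a plain hydrogen at the same place would read. They also leave open whether trifluoromethoxy would read the same alongside the other features of compound 1, which differs from compound 3 in more than one place.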